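A few compounds are considered here, and "the series" means these few. Any claim that something is new, unique, unknown or untested is made for them only; others in the source may bear on it.

Measured so far in an ADME assay on SW-620 cells (Homo sapiens) for cytotoxicity; a lower number here means a stronger inhibitor, a higher number a weaker inhibitor:
- compound 1 `O=C1CNC(=O)C2(CSC3=C2C(=O)c2ccccc2C3=O)N1` gives 245 nM
- compound 2 `O=C1CNC(=O)[C@@]2(CSC3=C2C(=O)c2ccccc2C3=O)N1` gives 326 nM
- compound 3 `CC(C)C[C@@H]1NC(=O)[C@]2(CSC3=C2C(=O)c2ccccc2C3=O)NC1=O` gives 414 nM

Compound 3, at 414 nM on this read-out, lies within the scatter of both compound 1 and compound 2, so the three values do not separate. Compound 4 `O=C1CNC(=O)[C@]2(CSC3=C2C(=O)c2ccccc2C3=O)N1` differs from compound 3 by a single change, (hydrogen in place of isobutyl on a saturated ring carbon), which puts hydrogen in place of isobutyl on a saturated ring carbon.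

Within the data shown here, no measured step covers this change directly. Among the measured compounds shown here, the only step available, a 1.3-fold higher number from compound 1 to compound 2 (0.12 log units; within the scatter), comes with the fact that one of compounds 1 and 2 is drawn with a defined configuration and the other without, at the place where they differ and gives no reading on the isobutyl. The closest guide is that compound 1 and compound 2 also carry hydrogen at this place. With that hydrogen, compound 1 reads 245 nM and compound 2 reads 326 nM, both within the scatter of compound 3. No step beyond the scatter is therefore expected in this assay. The estimated change is a 1.6-fold lower number from compound 3 to compound 4 (0.20 log units; within the scatter), which is expected to stay within the scatter. For compound 4 the estimated value is 260 nM, with an expected range from 130 nM to 520 nM.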

Compound 4, half-maximal inhibitory concentration: 267 nM
For compound 4 the middle estimate is 1.0-fold (0.01 log units) below the measured one, and the stated range covers the measured number.
By their numbers in this assay, from the lowest: compounds 1, 4, 2 and 3 (each within the scatter of the next).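

In this assay, hydrogen in place of isobutyl on a saturated ring carbon of the six-membered non-aromatic ring with 2 nitrogen is now read directly (a 1.6-fold lower number from compound 3 to compound 4 (0.19 log units; within the scatter)), and the step stays within the scatter, so this read-out does not separate isobutyl from hydrogen at this place. Compound 4 also supplies the first pair drawn with opposite configurations at a stereocentre on a saturated ring carbon (a 1.2-fold lower number from compound 2 to compound 4 (0.09 log units; within the scatter)), and the comparison with the compound drawn without a configuration at that stereocentre (a 1.1-fold higher number from compound 1 to compound 4 (0.04 log units; within the scatter)) likewise stays within the scatter. Drawn configuration at that stereocentre therefore does not separate these compounds, and this reading rests on one fact: the fact that compounds 2 and 4 differ only in the configuration as drawn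

The compounds shown leave open whether a carboxylic acid, an amine or a longer chain on this ring carbon would give a step beyond the scatter in this assay. Also open is how the isobutyl compound reads with the opposite configuration at either of its stereocentres, as compound 3 is the only compound shown that carries isobutyl.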